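Plasma binding: piperazinyl in place of dimethylamino

The source may report more compounds than this note shows. Statements on the series, on what has been measured and on what is new or still open speak of the compounds shown alone.

Compound 2 `CNc1nccc(N2CC[C@H](NC(=O)Nc3ccc(CN(C)C)c(C(F)(F)F)c3)C2)n1` gives 87.8% in an ADME assay on a cell-free system (plasma, Mus musculus) for protein binding, and has the highest unbound fraction of the three compounds measured. Compound 1 `CNc1nccc(N2CC[C@H](NC(=O)Nc3ccc(Cl)c(C(F)(F)F)c3)C2)n1` gives 99.8% and compound 3 `CNc1nccc(N2CC[C@H](NC(=O)Nc3ccc(OC(F)F)cc3)C2)n1` gives 96.8%. For the measured compounds named here, the one single-point step known is a 61-fold higher unbound fraction from compound 1 to compound 2 (1.79 log units; beyond the scatter). Compound 4 `CNc1nccc(N2CC[C@H](NC(=O)Nc3ccc(CN4CCN(C)CC4)c(C(F)(F)F)c3)C2)n1` differs from compound 2 by 4-methylpiperazin-1-yl in place of dimethylamino on a saturated chain carbon bound to an aromatic carbon. Going by the values given here, the step from compound 1 to compound 2 bears on this change only loosely, as it brought in the (dimethylamino)methyl group that compound 4 keeps on the same saturated chain carbon; no measured pair shows the exchange of dimethylamino for 4-methylpiperazin-1-yl itself. The step in this assay is therefore expected to be small, without a clear direction beyond the scatter, a 1.1-fold higher unbound fraction from compound 2 to compound 4 (0.06 log units; within the scatter). Compound 4 is expected to give 86%, within 72% to 94%.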

Compound 4, plasma protein binding: 85.8%
Compound 4: middle estimate off by 1.0-fold (0.01 log units) (unbound fraction), on the low side; low and high end bracket the measured number.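

At this saturated chain carbon, a 1.2-fold higher unbound fraction from compound 2 to compound 4 (0.07 log units; within the scatter) shows that this assay does not separate 4-methylpiperazin-1-yl from dimethylamino. The large change from chloro is also not confined to (dimethylamino)methyl: (4-methylpiperazin-1-yl)methyl gives a 71-fold higher unbound fraction from compound 1 to compound 4 (1.85 log units; beyond the scatter) in this assay as well. Nothing available explains this result.

Open, on these data alone, is whether a morpholine or a carboxylic acid on the same saturated chain carbon would keep this unbound fraction. Also open, as far as these compounds go, is whether (4-methylpiperazin-1-yl)methyl would give a similar step on the core of compound 3.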